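Compound 2 to compound 4: chloro in place of bromo

The compounds below may be only part of what the source reports. "The series", "measured", "known", "first", "only" and "open" are said of these compounds alone.

In a functional assay on the whole organism (strain Kunming) with Mus musculus as the target, with a stated time of 0.5 h (on this read-out lower numbers stand for an effect already at smaller amounts and higher numbers for an effect only at larger amounts of compound), compound 1 (`COc1ccccc1/C=C/C(=O)OC/C=C/c1cc(OC)c(OC)cc1OC`) gives 101 umol/kg, compound 2 (`COc1cc(OC)c(OC)cc1/C=C/COC(=O)/C=C/c1ccc(Br)cc1`) gives 143 umol/kg and compound 3 (`COc1cc(OC)c(OC)cc1/C=C/COC(=O)/C=C/c1ccc(OC)c(OC)c1OC`) gives 75.1 umol/kg. The value of compound 2 lies within the scatter of both others. Compound 4 (`COc1cc(OC)c(OC)cc1/C=C/COC(=O)/C=C/c1ccc(Cl)cc1`) differs from compound 2 as follows: chloro in place of bromo on an aromatic carbon. This puts chloro in place of bromo on an aromatic carbon. Within the data shown here, the one measured step, a 1.4-fold higher number from compound 1 to compound 2 (0.15 log units; within the scatter), has 4-bromophenyl in place of 2-methoxyphenyl and stays within the scatter, so no step beyond the scatter is expected in this assay. Among the measured compounds shown here, no measured step exchanges bromo for chloro. The expected change is a 1.2-fold lower number from compound 2 to compound 4 (0.08 log units; within the scatter). Compound 4 is estimated at 120 umol/kg, with an expected range of 65 umol/kg to 220 umol/kg.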

Compound 4, dose for half-maximal effect: 137 umol/kg
Beside the measured number, compound 4's estimate is 1.1-fold (0.06 log units) below it; the measured number falls inside the stated range.
By their numbers in this assay, from the lowest: compounds 3, 1, 4 and 2 (each within the scatter of the next).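

On the aromatic carbon para to a large group, chloro in place of bromo gives a 1.0-fold lower number from compound 2 to compound 4 (0.02 log units; within the scatter) in this assay, the first direct read of a change at this position with the rest of the molecule held constant. Exchanging this halogen therefore produces no step beyond the scatter, and 4-chlorophenyl in place of 2-methoxyphenyl, at a 1.4-fold higher number from compound 1 to compound 4 (0.13 log units; within the scatter), also stays within it. No measurement at hand offers an explanation for these results.

The compounds shown leave open whether an amine or a carboxylic acid on this aromatic carbon would give a step beyond the scatter.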